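Working notes: dimethylamino for methyl on the pendant ring

A few compounds are considered here, and "the series" means these few. Any claim that something is new, unique, unknown or untested is made for them only; others in the source may bear on it.

Measured so far:
compound 1 `Cc1ccc2c(=O)[nH]c(-c3ccccc3C)nc2c1`, 100%
compound 2 `O=c1[nH]c(-c2cccc3ccccc23)nc2ccc(N3CCCCC3)cc12`, 100%

In an assay on isolated protein for inhibition of DNA topoisomerase 1 (Homo sapiens), with a stated time of 30 min, tested at 100 uM (on this read-out lower numbers stand for a weaker effect and higher numbers for a stronger effect at the one concentration tested), compound 1 gives 100%. Compound 2 gives 100% in this assay, and the two values lie within the scatter of each other, so compound 1 stands level with compound 2. Among the compounds with values here, no step between measured compounds is available, so no size of step can be taken from the data.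

Compound 3 `Cc1ccc2c(=O)[nH]c(-c3ccccc3N(C)C)nc2c1` is not yet measured. It differs from compound 1 by dimethylamino in place of methyl on an aromatic carbon. The step of a number 5 percentage points lower from compound 1 to compound 3 (within the scatter) is expected to stay within the scatter. Compound 3 is estimated at 95%, with a range from 75% to 100%.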

Compound 3, a percentage reported as inhibition, at one concentration (the size of the read-out at that concentration, not a potency): 82.1%
Estimate against measurement, compound 3: 12.9 percentage points above, and the stated range covers the measured number.
By their numbers in this assay, from the lowest: compound 3; then compounds 1 and 2 (each within the scatter of the next).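

In this assay, within the data shown here, the aromatic carbon ortho to a large group is sensitive to the group it carries: dimethylamino in place of methyl gives a number 17.9 percentage points lower from compound 1 to compound 3 (beyond the scatter) and this modest step is the first size of change available. Even so, compound 3 retains 82.1% at the one concentration tested, so the larger group is accepted here with only a partial loss. No measurement on hand bears on the reason for this step.

Open, on these data alone, is whether a primary amine or a methoxy group on this carbon would stay level with compound 1. Also open, as far as these compounds go, is whether the same exchange would give a step of similar size on another core.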